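Extending the chain of compound 2: expectation before measurement

The compounds below may be only part of what the source reports. "The series", "measured", "known", "first", "only" and "open" are said of these compounds alone.

Compound 2 `CCCCCCOP(=O)(O)OCCSC(=S)N1CCN(C)CC1` carries 4-methylpiperazin-1-yl on the thiocarbonyl carbon. In an ADME assay on HEK293 cells (Homo sapiens) for inhibition, read by MTT assay, with stated times of 18 h and 4 h (on this read-out higher numbers stand for weaker inhibition and lower numbers for stronger inhibition), compound 2 gives only a limit, > 100000 nM. Compound 1 `CCCCCCOP(=O)(O)OCCSC(=S)N1CCCCCC1` gives 70500 nM in this assay. Compound 3 `CCCCCCOP(=O)(O)OCCSC(=S)N1CCCC1` gives a limit, > 100000 nM. Compound 2 therefore sits at the upper edge of the numbers shown, described by the limit of > 100000 nM in this assay, at which 2 of the 3 values shown sit.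

The measured steps all vary the ring on the thiocarbonyl carbon: an at least 1.4-fold higher number from compound 1 to compound 2 (0.15 log units; that floor lies within the scatter), an at least 1.4-fold higher number from compound 1 to compound 3 (0.15 log units; that floor lies within the scatter), and a step that the two limits leave unreadable from compound 2 to compound 3. None of them touches the chain.

Compound 4 `CCCCCCCCOP(=O)(O)OCCSC(=S)N1CCN(C)CC1` differs from compound 2 by ethyl in place of hydrogen on a saturated chain carbon, six bonds along the chain from an oxygen on an unsaturated carbon. Going by the values given here, no measured step bears on this change, so its size cannot be read from the series; the only guide is that every value shown lies at or near the limit. The step that the limit leaves unreadable from compound 2 to compound 4 is therefore expected to stay within the scatter. Compound 4 is expected to give 150000 nM, in the range 50000 nM to 500000 nM, most likely as a limit again.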

Compound 4, half-maximal inhibitory concentration: 86000 nM
Compound 4: middle estimate off by 1.7-fold (0.24 log units), on the high side, within the range that was stated.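

In this assay, the chain position gets its first reading: ethyl in place of hydrogen on a saturated chain carbon, six bonds along the chain from an oxygen on an unsaturated carbon, gives an at least 1.1-fold lower number from compound 2 to compound 4 (0.06 log units; that floor lies within the scatter). Compound 2 is recorded only as a limit of the assay, > 100000 nM, whereas the chain change in compound 4 yields a number rather than a limit. The full size of the step cannot be read because one end of it is a limit: the limit of > 100000 nM in this assay, at which 2 of the 4 values shown sit.

From the compounds shown here alone, it remains open what a longer chain such as decyl, or a terminal amine or carboxylic acid on the chain, would do with 4-methylpiperazin-1-yl on the thiocarbonyl carbon. Also open, going by these compounds, is whether the same chain change would read alike with azepan-1-yl or pyrrolidin-1-yl in that place.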